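This account rests on a few compounds, and the source may have more. Where it says the series, first, only, none or still open, it means among the compounds named here.

Of the compounds shown here, three from this series have been tested in an assay (Equus caballus) for inhibition of Thromboxane-A synthase (Homo sapiens), using microsomes; a lower number here means a stronger inhibitor, a higher number a weaker inhibitor. Compound 1, with the structure `NC(=O)CCCC/C=C(\c1ccccc1)c1cccnc1`, gives 400 nM. Compound 2, with the structure `O=C(O)CCCCCCCCC/C=C(/c1ccccc1)c1cccnc1`, gives 520 nM. Compound 3, with the structure `CC(C)(CCC/C=C(/c1ccccc1)c1cccnc1)C(=O)O`, gives 30 nM. Among these three results, compound 2 has the highest number, which in this assay means the weakest inhibition. Its result sits close to that of compound 1, and the gap between the two lies within the usual scatter of repeat measurements, so no order between them can be claimed. The gap to compound 3 is wider and lies beyond the scatter, so compound 3 is the stronger inhibitor of that pair.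

The next compound to consider is compound 4, with the structure `O=C(O)CCCCCCCCC/C=C(\c1ccccc1)c1cccnc1`. Compared with compound 2, the difference is this: the two compounds have the same atoms and bonds and differ only in configuration as drawn: 1 of 1 stereo elements differ; a double bond is drawn Z in compound 2 and E in compound 4. Within the data shown here, no pair among the measured compounds isolates this kind of change, so there is no measured step to lean on. For a change in the drawn geometry of the double bond alone, a step of modest size in either direction is plausible, and a result within the scatter is also possible. Taking compound 2 as the anchor, the expected result for compound 4 in this assay is 350 nM, with a range from 90 nM to 1500 nM. That estimate means an expected step of a 1.5-fold lower number from compound 2 to compound 4 (0.17 log units; within the scatter).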

Compound 4, half-maximal inhibitory concentration: 55 nM
Compound 4: the middle estimate sits 6.4-fold (0.80 log units) above what was measured; measured number below the stated range.
By their numbers in this assay, from the lowest: compounds 3 and 4 (each within the scatter of the next); then compounds 1 and 2 (each within the scatter of the next).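

In this assay, the drawn geometry of the double bond proves to matter on its own, with a 9.5-fold lower number from compound 2 to compound 4 (0.98 log units; beyond the scatter). Among these compounds, no earlier pair could show this, and the comparison here is unusually clean, since nothing else separates the two compounds: the fact that compounds 2 and 4 differ only in the configuration as drawn. Among the compounds shown here, the result also gives a first reading of a change at the end of the chain, with a 7.3-fold lower number from compound 1 to compound 4 (0.86 log units; beyond the scatter), where 5-carboxypentyl stands in place of carbamoyl; this step is the larger change in structure, so it says less about any single feature than the step between the two geometric forms.

The compounds shown leave open whether the same switch in geometry would give a step of similar size on a shorter chain, on the chain with the two added methyl groups seen in compound 3, or with the carbamoyl group of compound 1. They also leave open whether a tetrazole or a hydroxamic acid at the chain end would keep the result seen for compound 4, and they do not explain why the geometry has this effect.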